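Swapping Methyl for Fluoro on a Shared Core

This account rests on a few compounds, and the source may have more. Where it says the series, first, only, none or still open, it means among the compounds named here.

Compound 1 `C=CCn1c(=O)/c(=C\c2cccc(C)c2)[nH]c(=O)/c1=C\c1ccccc1OC`: 32800 nM
Compound 2 `COc1ccccc1/C=c1/[nH]c(=O)/c(=C\c2ccccc2OC)[nH]c1=O`: "not active" (no number reported)
Compound 3 `C=CCn1c(=O)/c(=C\c2ccc(Cl)c(Cl)c2)[nH]c(=O)/c1=C\c1ccccc1`: "not active" (no number reported)

Within the data shown here, in a functional assay on NCI-H1975 cells (Homo sapiens) for cytotoxicity, read by CCK-8 assay, with a stated time of 72 h (a higher number here means a weaker inhibitor, a lower number a stronger inhibitor), compound 1 gives 32800 nM, the only number reported among the three measured compounds. Compound 2 is reported as "not active" (no number reported), and compound 3 as "not active" (no number reported), so neither offers a value to compare against. Compound 4 `C=CCn1c(=O)/c(=C\c2cccc(F)c2)[nH]c(=O)/c1=C\c1ccccc1OC` differs from compound 1 in one place: fluoro in place of methyl on an aromatic carbon. Among the measured compounds shown here, no measured pair shows what this particular change does in this assay, so the expectation rests on the single number for compound 1 alone. The step from compound 1 to compound 4 is expected to be small, within the scatter of repeated measurements, at a 1.2-fold higher number from compound 1 to compound 4 (0.09 log units; within the scatter). Compound 4 is therefore estimated at 40000 nM, with a range from 15000 nM to 100000 nM.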

Compound 4, half-maximal inhibitory concentration: 25600 nM
Estimate against measurement, compound 4: 1.6-fold (0.19 log units) above; the range from low to high includes it.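

Fluoro in place of methyl on this aromatic carbon gives a 1.3-fold lower number from compound 1 to compound 4 (0.11 log units; within the scatter) in this assay, so the two compounds cannot be told apart. This is the first pair shown that differs in only one place, and it shows that activity at this level does not depend on keeping the 3-methylphenyl group, as 3-fluorophenyl serves equally. No measurement here explains why the two read alike.

On these data alone, each group has a single heavy atom, so it remains open what a carboxylic acid or a longer chain such as butyl would do on this carbon. As far as these compounds go, it is also open whether any group here could move the number beyond the scatter.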